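The source may report more compounds than this note shows. Statements on the series, on what has been measured and on what is new or still open speak of the compounds shown alone.

Working notes on a small series built on one shared core, three compounds measured and one still open. Compound 1 `CC(C)Cc1nn(C)c(=O)c2c(SCCCO)n(Cc3ccc(Br)c4ccccc34)cc12` gives 11 nM in an assay on Raji cells for inhibition of Monocarboxylate transporter 1 (Homo sapiens), read by MTT assay, with a stated time of 96 h; a lower number here means that less compound is needed, a higher number that more compound is needed for the effect. Compound 3 `CC(C)Cc1nn(C)c(=O)c2c(SCCCO)n(Cc3cnc(NCCCCCN)c4ccccc34)cc12` gives 0.8 nM in this assay. Compound 2 `CC(C)Cc1nn(C)c(=O)c2c(SCCCO)n(Cc3ccc(NCCCCCNC(=O)[C@@H](N)CCC(N)=O)nc3)cc12` gives 100 nM in this assay, the highest of the three numbers; compound 1 stands nearest with a lower number, compound 3 furthest with a much lower one, and both gaps are beyond the scatter.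

Compound 4 `CC(C)Cc1nn(C)c(=O)c2c(SCCCO)n(Cc3ccc(NCCCCCN)nc3)cc12` is the next candidate for this assay. It differs from compound 2 by hydrogen in place of (1-amino-3-carbamoylpropyl)carbonyl on an amine nitrogen. For the measured compounds named here, no pair of measured compounds differs in a single place, so there is no measured step of the same kind to anchor this change. Compound 2 and compound 3 both carry a five-carbon chain on the aromatic part, and the two values show a wide gap between them. The step from compound 2 to compound 4 is expected to be a 6.7-fold lower number from compound 2 to compound 4 (0.82 log units; beyond the scatter), a move to a lower number beyond the scatter, because the free-amine compound 3 gives 0.8 nM. Compound 4 is therefore estimated at 15 nM, with a range from 3 nM to 60 nM.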

Compound 4, half-maximal effective concentration: 420 nM
Compound 4: middle estimate off by 28-fold (1.45 log units), on the low side; measured number above the stated range.
By their numbers in this assay, from the lowest: compound 3; then compound 1; then compound 2; then compound 4.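

Replacing the (1-amino-3-carbamoylpropyl)carbonyl by hydrogen on the amine nitrogen gives a 4.2-fold higher number from compound 2 to compound 4 (0.62 log units; beyond the scatter) in this assay. For the compounds shown here, this is the first step that can be read at a single place, and its direction is clear: at this chain end, the acylated nitrogen of compound 2 gives the lower number and the free amine of compound 4 the higher one. The group that leaves is therefore tolerated at this position in this assay, and its loss does not lower the number. No measurement in hand says why the number moves this way.

The step does not show which part of the departing group matters: an acetyl on the same nitrogen would test the amide link alone, while a carboxylic acid in place of the terminal carbamoyl, or removal of the amino group, would probe the rest of the side chain. From the compounds shown here alone, the role of the defined stereocentre remains open as well, as does the effect of a shorter or longer chain carrying the same terminal amine or amide.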